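This account rests on a few compounds, and the source may have more. Where it says the series, first, only, none or still open, it means among the compounds named here.

In a functional assay on MDA-MB-231 cells (Homo sapiens) for inhibition, read by MTT assay, with a stated time of 24 h (on this read-out higher numbers stand for weaker inhibition of growth and lower numbers for stronger inhibition of growth), compound 1 (`N[C@@H](CC(=O)OC[C@H]1O[C@@H](n2cc(F)c(=O)[nH]c2=O)C[C@@H]1OC(=O)C[C@H](N)C(=O)O)C(=O)O`) gives 33100000 nM and compound 2 (`N[C@@H](CCC(=O)O[C@H]1C[C@H](n2cc(F)c(=O)[nH]c2=O)O[C@@H]1CO)C(=O)O`) gives 34900000 nM on the same read-out. These two values lie within the usual scatter of each other, so compound 2 stands level with compound 1 in this small set. Compound 3 (`N[C@@H](CC(=O)O[C@H]1C[C@H](n2cc(F)c(=O)[nH]c2=O)O[C@@H]1CO)C(=O)O`) has yet to be measured and differs from compound 2 in one place: amino(carboxy)methyl in place of 2-amino-2-carboxyethyl on a saturated chain carbon bound to a carbonyl carbon on a saturated chain carbon bound to a carbonyl carbon. Going by the values given here, no measured pair shows this change on its own, so nothing beyond the scatter is expected in this assay in either direction. The closest guide is compound 2 at 34900000 nM in the same test. The estimated 1.0-fold lower number from compound 2 to compound 3 (0.01 log units; within the scatter) is therefore small and lies within the scatter. For compound 3 the expected value is 34000000 nM with an estimated range from 15000000 nM to 75000000 nM in this test.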

Compound 3, concentration for 50% growth inhibition: 37600000 nM
Beside the measured number, compound 3's estimate is 1.1-fold (0.04 log units) below it, within the range that was stated.
By their numbers in this assay, from the lowest: compounds 1, 2 and 3 (each within the scatter of the next).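

In this assay, the shorter amino(carboxy)methyl in place of 2-amino-2-carboxyethyl on a saturated chain carbon bound to a carbonyl carbon gives a 1.1-fold higher number from compound 2 to compound 3 (0.03 log units; within the scatter), so this single change of chain length leaves the read-out unmoved at this position. Compound 1 and compound 3 also differ in one place: hydrogen in place of (2-amino-2-carboxyethyl)carbonyl on an oxygen on a saturated carbon gives a 1.1-fold higher number from compound 1 to compound 3 (0.06 log units; within the scatter), so this change too makes no difference that can be told from the scatter. Nothing at hand offers a reason for either result.

The compounds shown leave open whether a longer chain on this carbonyl carbon would move the read-out. They also leave open whether a chain bearing only an amine, or only a carboxylic acid, would behave as these do.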